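The source may report more compounds than this note shows. Statements on the series, on what has been measured and on what is new or still open speak of the compounds shown alone.

In a functional assay on HL-60 cells (Homo sapiens), with a stated time of 4 days (a lower number here means a stronger inhibitor, a higher number a weaker inhibitor), compound 1 `Cc1ccc(CNC(=O)c2[nH]cnc2C(=O)Nc2ccc(Cl)c(Cl)c2)cc1` gives 15200 nM, the highest number of the two measured compounds. Compound 2 `C[C@H](NC(=O)c1[nH]cnc1C(=O)Nc1ccc(Cl)c(Cl)c1)c1ccccc1` gives 5900 nM in this assay, and the step of a 2.6-fold lower number from compound 1 to compound 2 (0.41 log units; beyond the scatter) places 1-phenylethyl in place of 4-methylbenzyl on the amide-type nitrogen. Compound 3 `COC(=O)[C@@H](NC(=O)c1[nH]cnc1C(=O)Nc1ccc(Cl)c(Cl)c1)C(C)C` differs from compound 1 in the same place: 1-(methoxycarbonyl)-2-methylpropyl in place of 4-methylbenzyl on an amide-type nitrogen. Going by the values given here, only the step from compound 1 to compound 2 bears on this change, and it shows that replacing the 4-methylbenzyl group by a branched group of the same size carries a modest gain, while here the six-membered aromatic ring of carbon leaves and no ring enters, so that gain cannot simply be carried over. Compound 3 is therefore expected to sit near compound 1, with a step of a 1.3-fold lower number from compound 1 to compound 3 (0.10 log units; within the scatter) not clearly beyond the scatter. The estimate for compound 3 in this assay is 12000 nM, within a range of 3500 nM to 40000 nM.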

Compound 3, half-maximal inhibitory concentration: > 62500 nM
Compound 3 gave a limit, no number (the forecaster's own chance of this, stated with the estimate: 15%); at least 5.2-fold (0.71 log units) between middle value and limit.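

In this assay compound 3 stands at a limit of the assay and not at a number: the limit of > 62500 nM in this assay, at which 1 of the 3 values shown sits. On the amide-type nitrogen, the change to 1-(methoxycarbonyl)-2-methylpropyl reads as an at least 4.1-fold higher number from compound 1 to compound 3 (0.61 log units; beyond the scatter) and as an at least 10-fold higher number from compound 2 to compound 3 (1.02 log units; beyond the scatter). The earlier pair showed only a modest shift between two groups that each carry a six-membered aromatic ring of carbon, whereas this result shows that a group of the same heavy-atom count with no ring and a methoxycarbonyl gives a much higher read-out at this position.

Compound 3 loses the ring and gains the methoxycarbonyl in one change, so the compounds shown do not separate the two. From the compounds shown here alone, whether a cyclohexyl group, an isobutyl chain or a carboxylic acid in place of the methoxycarbonyl would return a measurable number stays open.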